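A few compounds are considered here, and "the series" means these few. Any claim that something is new, unique, unknown or untested is made for them only; others in the source may bear on it.

Three measured compounds share one core and differ only in the group carried on the chain attached to the amide. Compound 1 `Cn1c(-c2ccc(NC(=O)CCl)cc2)nc(-c2ccccc2)c1-c1ccccc1` carries a chloro there, compound 2 `Cc1ccc2oc(SCC(=O)Nc3ccc(-c4nc(-c5ccccc5)c(-c5ccccc5)n4C)cc3)nc2c1` a (5-methyl-1,3-benzoxazol-2-yl)sulfanyl, and compound 3 `Cn1c(-c2ccc(NC(=O)CSc3nc4ccccc4s3)cc2)nc(-c2ccccc2)c1-c1ccccc1` a (1,3-benzothiazol-2-yl)sulfanyl. In a functional assay on MCF7 cells (Homo sapiens) for cytotoxicity, read by MTT assay, with a stated time of 24 h, tested at 1.6 ug/mL (a lower number here means a weaker effect, a higher number a stronger effect of the compound at the concentration tested), compound 1 gives 4.3%, compound 2 gives 1.9%, and compound 3 gives 2.1%. On the bare numbers compound 2 stands at the bottom of the three, but the step from compound 1 was a number 2.4 percentage points lower from compound 1 to compound 2 (within the scatter) and the step to compound 3 was a number 0.2 percentage points higher from compound 2 to compound 3 (within the scatter), so all three compounds are, in effect, equally weak at this concentration.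

Compound 4 `Cc1nnc(SCC(=O)Nc2ccc(-c3nc(-c4ccccc4)c(-c4ccccc4)n3C)cc2)s1` is the next variation at the same place: 5-methyl-1,3,4-thiadiazol-2-yl in place of 5-methyl-1,3-benzoxazol-2-yl on a sulfur. Among the compounds with values here, the steps that bear on this exchange are a number 2.4 percentage points lower from compound 1 to compound 2 (within the scatter), a number 2.2 percentage points lower from compound 1 to compound 3 (within the scatter) and a number 0.2 percentage points higher from compound 2 to compound 3 (within the scatter); each swapped the group on this sulfur or replaced the chloro by such a group, and none moved the read-out beyond the scatter. The expected step in this assay is therefore a number 0.6 percentage points higher from compound 2 to compound 4 (within the scatter), with no direction beyond the scatter. Compound 4 is estimated at 2.5%, with a likely range from 0% to 9%.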

Compound 4, a percentage reported as activity, at one concentration (the size of the read-out at that concentration, not a potency): 37.5%
The estimate for compound 4 lay 35 percentage points below the measured number; measured number outside the range, above it.
By their numbers in this assay, from the lowest: compounds 2, 3 and 1 (each within the scatter of the next); then compound 4.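

The group on this sulfur does matter in this assay: swaps among the earlier groups stayed within the scatter, yet the new group gives a number 35.6 percentage points higher from compound 2 to compound 4 (beyond the scatter) and a number 35.4 percentage points higher from compound 3 to compound 4 (beyond the scatter) as well. The gain is also large against the chloro, with a number 33.2 percentage points higher from compound 1 to compound 4 (beyond the scatter). Compound 2 and compound 3 stay within the scatter of compound 1, so a sulfanyl group as such does not bring the gain, and among these compounds only the (5-methyl-1,3,4-thiadiazol-2-yl)sulfanyl does. This exchange changes several things at once, replacing a group of two aromatic rings with a smaller one of a single ring that holds three hetero atoms, one of them sulfur, and no available measurement indicates which of these changes counts.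

The compounds shown leave open whether the methyl on the thiadiazole is needed, and whether a 1,3,4-oxadiazol-2-yl or a 4H-1,2,4-triazol-3-yl on the same sulfur would serve as well. They also leave open whether the sulfur itself can give way to an amine such as morpholine on the same chain carbon.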